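Trifluoromethyl for methyl, tried again on a second core

The source may report more compounds than this note shows. Statements on the series, on what has been measured and on what is new or still open speak of the compounds shown alone.

Two related cores appear here. Compound 1 `Cc1ccc(Nc2nccc(-c3ccnc4ccccc34)n2)cc1` and compound 2 `FC(F)(F)c1ccc(Nc2nccc(-c3ccnc4ccccc34)n2)cc1` share one core; compound 3 `Cc1ccc(Nc2nccc(-c3c(C)nc4ccccn34)n2)cc1` and the not yet measured compound 4 `Cc1nc2ccccn2c1-c1ccnc(Nc2ccc(C(F)(F)F)cc2)n1` share another. The difference between the two cores is not broken down here.

In a functional assay on MCF7 cells (Homo sapiens) for cytotoxicity, read by sulforhodamine B assay, with a stated time of 48 h (on this read-out higher numbers stand for weaker inhibition and lower numbers for stronger inhibition), compound 1 gives 600 nM, and compound 2 gives 1650 nM. The change between them, (trifluoromethyl in place of methyl on an aromatic carbon), produced a 2.8-fold higher number from compound 1 to compound 2 (0.44 log units; beyond the scatter). In this assay compound 3 gives 59 nM, the lowest of the three numbers and well apart from both compound 1 and compound 2.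

Compound 4 differs from compound 3 by trifluoromethyl in place of methyl on an aromatic carbon. The place is described in the same words for both pairs, so this is the same change made on the second core. Among the compounds with values here, the only guide to its effect is the single earlier pair, so the expectation for compound 4 is that the step from compound 3 will be about the size of the one seen before, that is a 2.8-fold higher number from compound 3 to compound 4 (0.45 log units; beyond the scatter) beside a 2.8-fold higher number from compound 1 to compound 2 (0.44 log units; beyond the scatter), resting on compound 1 and compound 2 alone. On that basis compound 4 is estimated to give about 165 nM in this assay, most likely between 70 nM and 400 nM.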

Compound 4, half-maximal inhibitory concentration: 66 nM
Beside the measured number, compound 4's estimate is 2.5-fold (0.40 log units) above it; the measured number lies below the stated range.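

On the second core, trifluoromethyl in place of methyl produced a 1.1-fold higher number from compound 3 to compound 4 (0.05 log units; within the scatter) in this assay and so left the number within the usual scatter of repeated measurements, whereas on the first core the same change produced a 2.8-fold higher number from compound 1 to compound 2 (0.44 log units; beyond the scatter) and moved the number beyond that scatter. Set side by side, however, the two steps cannot be called different from each other: the same change on two cores in this assay, a 2.8-fold higher number (0.44 log units; beyond the scatter) from compound 1 to compound 2 and a 1.1-fold higher number (0.05 log units; within the scatter) from compound 3 to compound 4, 2.5-fold (0.39 log units) apart, within the scatter of two such steps. This means there is no firm sign that the core alters the effect of this change, but it does not show that the effect carries over unchanged either; one step lies beyond the scatter and the other within it, and two pairs are too few to settle the matter.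

The compounds shown leave open how other groups at the same place would behave on these two cores, such as a chlorine atom, a methoxy group or an amine, and whether any of them would shift the number by a similar amount on both. They also leave open whether trifluoromethyl in place of methyl would give a similar step on a third core, where a further pair could show whether the two steps seen so far truly agree.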